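From piperazine to 1,4-diazepane on a shared core

This account rests on a few compounds, and the source may have more. Where it says the series, first, only, none or still open, it means among the compounds named here.

In an ADME assay on CHO cells (Cricetulus griseus) for cytotoxicity, read by MTT assay (a higher number here means that more compound is tolerated, a lower number that less compound is tolerated), compound 1 `CN1CCN(c2nccc3nc(-c4ccc(F)c(F)c4)[nH]c23)CC1` gives 50000 nM. Compound 3 `C[C@@H]1CN(c2nccc3[nH]c(-c4ccc(F)c(F)c4)nc23)C[C@H](C)N1C` gives > 50000 nM, which is a limit of the assay. Compound 2 `Fc1ccc(-c2nc3c(N4CCNCC4)nccc3[nH]2)cc1F` has the lower of the two actual numbers at 8100 nM, a gap to compound 1 that lies beyond the scatter. Compound 4 `Fc1ccc(-c2nc3c(N4CCCNCC4)nccc3[nH]2)cc1F` differs from compound 2 in one place, with 1,4-diazepan-1-yl in place of piperazin-1-yl on an aromatic carbon. Within the data shown here, no measured pair shows this change, and the hydrogen-bond donor and acceptor counts stay the same, so no step beyond the scatter is expected in this assay. The estimated step of a 1.1-fold higher number from compound 2 to compound 4 (0.05 log units; within the scatter) is correspondingly small. For compound 4, the expected value is 9000 nM, with an estimated range of 3000 nM to 30000 nM.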

Compound 4, half-maximal cytotoxic concentration: 7200 nM
Estimate against measurement, compound 4: 1.3-fold (0.10 log units) above; measured number inside the range.
By their numbers in this assay, from the lowest: compounds 4 and 2 (each within the scatter of the next); then compound 1.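

Among these compounds, replacing the six-membered non-aromatic ring with a seven-membered one, next to the ring nitrogen, gives the first one-place step in this assay: a 1.1-fold lower number from compound 2 to compound 4 (0.05 log units; within the scatter). At this position, the seven-membered ring and the six-membered ring cannot be told apart in this read-out. Nothing measured here gives a reason for this result. From the compounds shown here alone, it remains open whether a methyl group on the free ring nitrogen of 1,4-diazepan-1-yl would shift the number in this assay. Going by these compounds, whether morpholine or an open-chain amine at this place would stay within the scatter also remains open.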